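The compounds below may be only part of what the source reports. "The series", "measured", "known", "first", "only" and "open" are said of these compounds alone.

Measured compounds:
Compound 1, `O=C(/C(=C\c1ccc(Cl)cc1Cl)S(=O)(=O)c1ccc(Br)cc1)c1ccc(Cl)cc1`, gives 50000 nM in a functional assay on DU-145 cells (Homo sapiens) for inhibition, read by trypan blue exclusion, with a stated time of 96 h; on this read-out lower numbers stand for stronger inhibition of growth and higher numbers for weaker inhibition of growth.
Compound 2, `O=C(/C(=C\c1ccc(Cl)cc1Cl)S(=O)(=O)c1ccc(Br)cc1)c1ccc(Br)cc1`, gives 10000 nM in this assay.

Within the data shown here, compound 2 stands lowest of the two numbers; its nearest neighbour is compound 1, and the one measured step, a 5.0-fold lower number from compound 1 to compound 2 (0.70 log units; beyond the scatter), is modest but beyond the scatter. Compound 3, `O=C(/C(=C\c1ccc(Br)c([N+](=O)[O-])c1)S(=O)(=O)c1ccc(Br)cc1)c1ccc(Br)cc1`, has not yet been measured in this assay. It differs from compound 2 in one place: 4-bromo-3-nitrophenyl in place of 2,4-dichlorophenyl on a double-bonded chain carbon bound to a double-bonded chain carbon. Among the measured compounds shown here, this is a larger change than the one measured step, since the whole aryl group on the chain carbon is exchanged and a nitro group enters, whereas the step from compound 1 to compound 2 exchanged a single halogen on the other aromatic ring. For the measured compounds named here, that step bears on the new one only loosely, as it too brings bromo in place of chloro, and there is no measured example of a nitro group here. A step from compound 2 to compound 3 of about a 1.4-fold lower number from compound 2 to compound 3 (0.15 log units; within the scatter) is therefore expected, toward a somewhat lower number but with wide uncertainty. Compound 3 is estimated at 7000 nM, within a range of 2000 nM to 30000 nM.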

Compound 3, concentration for 50% growth inhibition: 10000 nM
Beside the measured number, compound 3's estimate is 1.4-fold (0.15 log units) below it; the measured number falls inside the stated range.
By their numbers in this assay, from the lowest: compounds 2 and 3 (each within the scatter of the next); then compound 1.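

Compound 3 shows that in this assay the whole aryl group on the double-bonded chain carbon can be exchanged, which the earlier pair did not touch: 4-bromo-3-nitrophenyl in place of 2,4-dichlorophenyl gives no change at the digits printed from compound 2 to compound 3 (within the scatter). So this position takes a larger group, with a nitro group and a bromine entering and both chlorines leaving, while the number stays within the scatter, whereas the single halogen exchange between compound 1 and compound 2 moved it beyond the scatter. The step changes several things at once, so a gain from one part could be cancelled by a loss from another, and nothing at hand tells why the number holds.

As far as these compounds go, the separate contributions of the nitro group and the bromine on this ring remain open, as does the question of whether either one alone would give the same number. Also open, from the compounds shown here alone, is how an amine, a carboxylic acid or a methoxy group on this ring would read, and whether any such group could bring the number clearly under that of compound 2.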